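The source may report more compounds than this note shows. Statements on the series, on what has been measured and on what is new or still open speak of the compounds shown alone.

Measured so far:
compound 1, `CC(C)c1cccc(C(C)C)c1NC(=O)NCC1(c2ccccc2C(F)(F)F)CCCC1`: 18 nM
compound 2, `CC(C)c1cccc(C(C)C)c1NC(=O)NCC1(c2cccc(C(=O)O)c2)CCCC1`: 620 nM

Both compounds share one core and differ only in the aromatic ring attached to a saturated ring carbon. Going by the values given here, in an assay on microsomes for inhibition of acyl-CoA:cholesterol acyltransferase (Oryctolagus cuniculus) (on this read-out lower numbers stand for stronger inhibition and higher numbers for weaker inhibition), compound 1 gives 18 nM, whereas compound 2 gives 620 nM, the highest of the two numbers; the single measured step, a 34-fold higher number from compound 1 to compound 2 (1.54 log units; beyond the scatter), is large.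

Compound 3, `Cc1ccc(C2(CNC(=O)Nc3c(C(C)C)cccc3C(C)C)CCCC2)c(C)c1`, is not yet measured. It differs from compound 2 in one place: 2,4-dimethylphenyl in place of 3-carboxyphenyl on a saturated ring carbon. Among the compounds with values here, the only step that bears on this change is the one from compound 1 to compound 2, which removed a 2-(trifluoromethyl)phenyl and brought in the 3-carboxyphenyl that now leaves again. Within the data shown here, since the group that enters, like the one in compound 1, carries no hydrogen-bond donor or acceptor, the expectation is a step back toward compound 1, of roughly the size seen before but in the opposite direction, estimated as a 21-fold lower number from compound 2 to compound 3 (1.32 log units; beyond the scatter). For compound 3 the estimated value in this assay is 30 nM, expected to fall between 8 nM and 120 nM.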

Compound 3, half-maximal inhibitory concentration: 50 nM
Compound 3: the middle estimate sits 1.7-fold (0.22 log units) below what was measured; low and high end bracket the measured number.
By their numbers in this assay, from the lowest: compound 1; then compound 3; then compound 2.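

In this assay, 2,4-dimethylphenyl in place of 3-carboxyphenyl on the saturated ring carbon gives a 12-fold lower number from compound 2 to compound 3 (1.09 log units; beyond the scatter). The much stronger inhibition of compound 1 is therefore not unique to its 2-(trifluoromethyl)phenyl, as a second aromatic group with no hydrogen-bond donor or acceptor also comes close to it, yet the two groups are not interchangeable, with a 2.8-fold higher number from compound 1 to compound 3 (0.44 log units; beyond the scatter). Nothing here gives a measured reason for either step.

The compounds shown leave open whether the weaker inhibition of compound 2 belongs to the carboxylic acid itself or would also appear with a methyl ester or a primary amide in its place. They also do not tell how an amine or a methoxy group on this aromatic ring would read.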